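A few compounds are considered here, and "the series" means these few. Any claim that something is new, unique, unknown or untested is made for them only; others in the source may bear on it.

Working notes on this series. Three amides sharing the core of compound 1 `O=C(COc1ccc2c(=O)ccoc2c1)Nc1cccc(NC(=O)c2ccccc2)c1` have been measured in an assay on isolated protein for inhibition of Rho-associated protein kinase 1 (Homo sapiens), read by scintillation counting, radiometric assay and 33P incorporation, with a stated time of 40 min, in the presence of a further agent that is not named here; on this read-out higher numbers stand for weaker inhibition and lower numbers for stronger inhibition; compound 1 gives 120 nM, compound 2 `O=C(COc1ccc2c(=O)ccoc2c1)Nc1cccc(NC(=O)c2ccc(Br)cc2)c1` gives 303 nM, and compound 3 `COC(=O)c1ccc(C(=O)Nc2cccc(NC(=O)COc3ccc4c(=O)ccoc4c3)c2)cc1` gives 72 nM. Going by the values given here, compound 3 thus stands at the lowest number of the three, separated from compound 1 by a 1.7-fold lower number from compound 1 to compound 3 (0.22 log units; within the scatter) and from compound 2 by a 4.2-fold lower number from compound 2 to compound 3 (0.62 log units; beyond the scatter); the step of a 2.5-fold higher number from compound 1 to compound 2 (0.40 log units; beyond the scatter) is the only other change measured. Compound 4 `O=C(COc1ccc2c(=O)ccoc2c1)Nc1cccc(NC(=O)c2cnc(C(F)(F)F)s2)c1` carries 2-(trifluoromethyl)-1,3-thiazol-5-yl in place of 4-(methoxycarbonyl)phenyl on a carbonyl carbon. Among the compounds with values here, no measured step exchanges the whole aromatic group on this carbonyl, and the two steps that reach compound 3 alter only one substituent on the phenyl, so they bear on it weakly. In this assay a step of about a 2.1-fold higher number from compound 3 to compound 4 (0.32 log units; beyond the scatter) is expected, most likely no change beyond the scatter or a small move toward the higher side. Compound 4 is estimated at 150 nM, within 50 nM to 450 nM.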

Compound 4, half-maximal inhibitory concentration: 160 nM
Compound 4: the middle estimate sits 1.1-fold (0.03 log units) below what was measured; measured number inside the range.
By their numbers in this assay, from the lowest: compounds 3, 1, 4 and 2 (each within the scatter of the next, the first and the last beyond it).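

In this assay this carbonyl position tolerates exchange of the whole aromatic group: 2-(trifluoromethyl)-1,3-thiazol-5-yl in place of phenyl gives a 1.3-fold higher number from compound 1 to compound 4 (0.12 log units; within the scatter) and in place of 4-bromophenyl gives a 1.9-fold lower number from compound 2 to compound 4 (0.28 log units; within the scatter) as a step, both within the scatter. Only the exchange for 4-(methoxycarbonyl)phenyl lies beyond the scatter (a 2.2-fold higher number from compound 3 to compound 4 (0.35 log units; beyond the scatter)). No evidence available here accounts for these steps. Still open, going by these compounds, is how a carboxylic acid or an amine on the thiazole or phenyl ring would read in this assay.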